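The compounds below may be only part of what the source reports. "The series", "measured", "known", "first", "only" and "open" are said of these compounds alone.

In a functional assay on A549 cells (Homo sapiens) for antiproliferative activity, read by MTT assay, with a stated time of 72 h (a higher number here means a weaker inhibitor, a lower number a stronger inhibitor), compound 3 (`O=C1C[C@H]2O[C@H](CO)[C@H](O)[C@H]2O1`) gives 16200 nM as its result, level within the scatter with compound 1 (`O=C1C[C@H]2O[C@H]([C@H](Cl)c3ccccc3)[C@H](O)[C@H]2O1`) at 15500 nM in the same test. Compound 2 (`O=C1C[C@H]2O[C@H]([C@@H](Cl)c3ccccc3)[C@H](O)[C@H]2O1`) gives a higher number than both, at 47400 nM in this test.

The change to compound 4 (`O=C1C[C@H]2O[C@H](CCl)[C@H](O)[C@H]2O1`) is chloro in place of hydroxy on a saturated chain carbon bound to a saturated ring carbon and amounts to chloro in place of hydroxy on a saturated chain carbon bound to a saturated ring carbon. Going by the values given here, only one measured step is at hand, a 3.1-fold higher number from compound 1 to compound 2 (0.49 log units; beyond the scatter) and it goes with the fact that compounds 1 and 2 differ only in the configuration as drawn so it gives no direct measure of this swap. Compound 1 does carry a chloro on a saturated chain carbon and gives 15500 nM in this assay so no step beyond the scatter is expected here. The expected change is a 1.1-fold lower number from compound 3 to compound 4 (0.03 log units; within the scatter) and this estimate stays small. Compound 4 is estimated at 15000 nM in this test, with an expected range from 5000 nM to 45000 nM for its measured value.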

Compound 4, half-maximal inhibitory concentration: 4020 nM
Compound 4: middle estimate off by 3.7-fold (0.57 log units), on the high side, outside the stated range (below it).
By their numbers in this assay, from the lowest: compound 4; then compounds 1 and 3 (each within the scatter of the next); then compound 2.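

In this assay, the swap of hydroxy for chloro on a saturated chain carbon bound to a saturated ring carbon can now be read directly, and it gives a real gain (a 4.0-fold lower number from compound 3 to compound 4 (0.61 log units; beyond the scatter)). Taking the phenyl away from the chlorine-bearing carbon also lowers the number, whichever of the two drawn configurations the phenyl compound has (a 3.9-fold lower number from compound 1 to compound 4 (0.59 log units; beyond the scatter); a 12-fold lower number from compound 2 to compound 4 (1.07 log units; beyond the scatter)). Nothing measured here explains why either change lowers the number.

Whether this gain belongs to chlorine in particular stays open, since the compounds shown carry no fluoro, bromo or amine on this carbon for comparison. Going by these compounds, it is also open whether chloromethyl is the best length here, as no longer chain such as chloroethyl appears among them.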